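The compounds below may be only part of what the source reports. "The series", "measured", "known", "first", "only" and "open" are said of these compounds alone.

Of the compounds shown here, two have been measured in a functional assay with metabotropic glutamate receptor 5 (Rattus norvegicus) as the target; on this read-out lower numbers stand for stronger inhibition and higher numbers for weaker inhibition. Compound 1 `COc1cc(C#N)cc(-n2nnc(-c3ccccn3)n2)c1` gives 10 nM in this assay, and compound 2 `N#Cc1cccc(-n2ccc(-c3ccccn3)c2)c1` gives 190 nM, the higher of the two numbers and well apart from compound 1, beyond the usual scatter. Compound 3 `N#Cc1cc(F)cc(-n2ccc(-c3ccccn3)c2)c1` differs from compound 2 in one place: fluoro in place of hydrogen on an aromatic carbon. Within the data shown here, no measured pair differs by this change alone. The step from compound 2 to compound 3 is expected to be a modest one toward a lower number, a 1.9-fold lower number from compound 2 to compound 3 (0.28 log units; within the scatter). Compound 3 is therefore expected to give about 100 nM in this assay, within a range from 30 nM to 350 nM.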

Compound 3, half-maximal inhibitory concentration: 3 nM
For compound 3 the middle estimate is 33-fold (1.52 log units) above the measured one; measured number below the stated range.
By their numbers in this assay, from the lowest: compound 3; then compound 1; then compound 2.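

In this assay, fluoro in place of hydrogen on this aromatic carbon, meta to a cyano group, produces a 63-fold lower number from compound 2 to compound 3 (1.80 log units; beyond the scatter). This position is therefore far from indifferent: a single added heavy atom here moves the number well beyond the scatter. Nothing available explains why the step is so large. On these data alone, whether this gain is particular to fluoro remains open. Chloro, a methyl group or an amine on the same carbon would show how much depends on the atom placed there.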